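Methyl for hydrogen at two places in a bicyclic series

The source may report more compounds than this note shows. Statements on the series, on what has been measured and on what is new or still open speak of the compounds shown alone.

Compound 1 `CCCCN(CC)c1cc(C)nc2c1NC(=O)CN2c1ccc(Br)cc1C` gives 4.4 nM in an assay on HEK-293T cells for displacement of a labelled ligand from corticotropin-releasing factor receptor 1 (Homo sapiens), read by scintillation counting, with a stated time of 2 h; a lower number here means a stronger inhibitor, a higher number a weaker inhibitor. Compound 3 `CCCCN(CC)c1cc(C)nc2c1NC(=O)CN2c1ccc(Br)cc1CC` carries one added carbon, (methyl in place of hydrogen on a saturated chain carbon bound to an aromatic carbon), and in this assay compound 3 gives 2.5 nM; the step of a 1.8-fold lower number from compound 1 to compound 3 (0.25 log units; within the scatter) is within the scatter, so the two compounds are not told apart. Compound 2 `Cc1cc(N(C)C)c2c(n1)N(c1ccc(C(C)C)cc1Br)CC(=O)N2CCCCF` rests on a differently arranged core; how the two cores differ is not broken down here. In this assay compound 2 gives 21.6 nM, the highest number of the three, beyond the scatter from both compound 1 and compound 3.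

Compound 4 `CCN(C)c1cc(C)nc2c1N(CCCCF)C(=O)CN2c1ccc(C(C)C)cc1Br` is not yet measured. It differs from compound 2 by methyl in place of hydrogen on a saturated chain carbon bound to a nitrogen on an aromatic ring, the same kind of change as between compound 1 and compound 3 but not the same: there the methyl entered on a saturated chain carbon bound to an aromatic carbon, here on a saturated chain carbon bound to a nitrogen on an aromatic ring. For the measured compounds named here, with only one earlier example, which moved nothing beyond the scatter, a similarly small step is expected, a 1.4-fold lower number from compound 2 to compound 4 (0.16 log units; within the scatter). Compound 4 is thus estimated at 15 nM in this assay, between 6 nM and 40 nM.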

Compound 4, inhibition constant: 13.9 nM
For compound 4 the middle estimate is 1.1-fold (0.03 log units) above the measured one; the range from low to high includes it.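

In this assay, going from dimethylamino to ethyl(methyl)amino gives a 1.6-fold lower number from compound 2 to compound 4 (0.19 log units; within the scatter), and compound 2 and compound 4 are not told apart. Set beside the earlier step, the added methyl gives a step of matching size on the two cores: the same change on two cores in this assay, a 1.8-fold lower number (0.25 log units; within the scatter) from compound 1 to compound 3 and a 1.6-fold lower number (0.19 log units; within the scatter) from compound 2 to compound 4, 1.1-fold (0.05 log units) apart, within the scatter of two such steps. This does not show that the change carries over at any one place: the methyl enters on a saturated chain carbon bound to an aromatic carbon in one pair and on a saturated chain carbon bound to a nitrogen on an aromatic ring in the other, and two steps within the scatter show no gain or loss from the change on either core.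

From the compounds shown here alone, it remains open whether a methyl at one and the same place would give matching steps on both cores. Also open, going by these compounds, is whether something larger than methyl at these places, such as a cyclopropyl ring or a chain ending in a hydroxyl, would move the number beyond the scatter.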